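Replacing the group on the carbonyl carbon of compound 2

The source may report more compounds than this note shows. Statements on the series, on what has been measured and on what is new or still open speak of the compounds shown alone.

Measured in an ADME assay on a cell-free system (plasma, Homo sapiens) for protein binding, read by LC-MS, with a stated time of 4 h, tested at 5 uM; a lower number here means a smaller unbound share, a higher number a larger unbound share of the compound:
compound 1 `O=C(NCc1ccc(S(=O)(=O)c2cccc(C(F)(F)F)c2)cc1)c1cc2cnccc2[nH]1`: 0.006
compound 2 `O=C(NCc1ccc(S(=O)(=O)c2cc(F)cc(F)c2)cc1)c1cc2cnccc2[nH]1`: 0.028

Going by the values given here, compound 2 holds the higher of the two numbers, and the only measured step is a 4.7-fold higher number from compound 1 to compound 2 (0.67 log units; beyond the scatter). Compound 3 `O=C(NCc1ccc(S(=O)(=O)c2cc(F)cc(F)c2)cc1)c1cnc2nccn2c1` differs from compound 2 in one place: a group of 9 heavy atoms (6 carbon, 3 nitrogen; one five-membered aromatic ring with 2 hetero atoms, one six-membered aromatic ring with 2 hetero atoms) in place of a group of 9 heavy atoms (7 carbon, 2 nitrogen; one five-membered aromatic ring with 1 hetero atom, one six-membered aromatic ring with 1 hetero atom), on a carbonyl carbon. No change at this place has been measured. Among the compounds with values here, the one step available was made on a sulfonyl sulfur, so it bears on the question only loosely. Within the data shown here, with compound 2 at 0.028 and the modest 4.7-fold higher number from compound 1 to compound 2 (0.67 log units; beyond the scatter) as the sole guide to size, a modest rise in this assay is tentatively expected, although the direction remains uncertain. The expected step is a 2.1-fold higher number from compound 2 to compound 3 (0.33 log units; beyond the scatter). For compound 3 the estimated value is 0.06, with an expected range of 0.022 to 0.15.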

Compound 3, unbound fraction: 0.122
The estimate for compound 3 lay 2.0-fold (0.31 log units) below the measured number; the measured number falls inside the stated range.
By their numbers in this assay, from the lowest: compound 1; then compound 2; then compound 3.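

In this assay, the group on the carbonyl carbon proves able to move the unbound fraction, with a 4.4-fold higher number from compound 2 to compound 3 (0.64 log units; beyond the scatter) as the first step read at this place. The entering group keeps the count of 9 heavy atoms but has 3 nitrogen rather than 2, and 0 hydrogen-bond donors and 3 hydrogen-bond acceptors where the group it replaces has 1 of each. Nothing available ties the rise to any one of these differences.

From the compounds shown here alone, with a single pair at this place, it remains open whether a plain phenyl or a morpholine on the carbonyl carbon would shift the number in the same direction. Going by these compounds, it is also open whether the same replacement would give a similar step with 3-(trifluoromethyl)phenyl on the sulfonyl sulfur.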